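A few compounds are considered here, and "the series" means these few. Any claim that something is new, unique, unknown or untested is made for them only; others in the source may bear on it.

Compound 1 `CN(C)CCCn1nc(C2=C(c3cn(C)c4ccccc34)C(=O)NC2=O)c2cccnc21`; compound 2 `Cn1cc(C2=C(c3nn(CCCN4CCCCC4)c4ncccc34)C(=O)N(c3ccccn3)C2=O)c2ccccc21`; compound 3 `Cn1cc(C2=C(c3nn(CCCCn4ccnc4)c4ncccc34)C(=O)NC2=O)c2ccccc21`.

In a functional assay on KB cells (Homo sapiens) for antiproliferative activity, read by MTT assay, with a stated time of 48 h (on this read-out higher numbers stand for weaker inhibition and lower numbers for stronger inhibition), compound 1 gives > 100000 nM, which is a limit of the assay and not a number. Compound 2 gives > 100000 nM in this assay, again only a limit. Compound 3 gives > 100000 nM in this assay, also a limit. Compound 2 therefore stands at a limit, and the two further values shown are limits as well: the limit of > 100000 nM in this assay, at which 3 of the 3 values shown sit.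

Compound 4 `Cn1cc(C2=C(c3nn(CCCN4CCCCC4)c4ncccc34)C(=O)N(c3cccc4ccccc34)C2=O)c2ccccc21` differs from compound 2 in one place: naphthalen-1-yl in place of pyridin-2-yl on an amide-type nitrogen in a ring.

Going by the values given here, the single measured step, a step that the two limits leave unreadable from compound 1 to compound 3, concerns a saturated chain carbon and not the amide-type nitrogen in a ring, and its size cannot be read because both ends sit at the limit. Among the compounds with values here, no measured step bears on the change from compound 2 to compound 4. With every value shown at the limit, the step from compound 2 to compound 4 is expected to be a number no higher from compound 2 to compound 4 (the limit leaves the size open), that is, nothing readable. Compound 4 is therefore expected to sit at the limit again, with an estimate of 100000 nM in this assay and a range from 30000 nM to 300000 nM.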

Compound 4, half-maximal inhibitory concentration: 13400 nM
Compound 4: the middle estimate sits 7.5-fold (0.87 log units) above what was measured, outside the stated range (below it).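

Going by these compounds alone, on the amide-type nitrogen in a ring, naphthalen-1-yl in place of pyridin-2-yl gives an at least 7.4-fold lower number from compound 2 to compound 4 (0.87 log units; beyond the scatter) in this assay, the first readable change, and it shows that this position can move the read-out. The pair alone does not tell which part of the change carries the step, since one six-membered aromatic ring with 1 hetero atom leaves and 2 six-membered aromatic rings of carbon only enter. The step from compound 1 to compound 3 cannot be read, and the earlier values gave no measure of any change: the limit of > 100000 nM in this assay, at which 3 of the 4 values shown sit.

Going by these compounds, whether a plain phenyl or a benzyl group on the same nitrogen would give a similar step remains open. Within the data shown here, also open is whether naphthalen-1-yl acts the same way with a chain other than the one in compound 4, such as a longer chain ending in a morpholine.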